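The compounds below may be only part of what the source reports. "The series", "measured", "known", "first", "only" and "open" are said of these compounds alone.

Compound 1 `COc1cc(OC)c2cc(-c3ccccc3)c(O)nc2c1` gives 10000 nM
Compound 2 `CCN(CC)C(=O)Cn1c(=O)c(-c2ccc(OC)cc2)cc2c(OC)cc(OC)cc21` gives 10000 nM

These two results come from a functional assay on T47D cells (Homo sapiens) for cytotoxicity, read by colorimetric assay and MTT assay (on this read-out lower numbers stand for stronger inhibition and higher numbers for weaker inhibition), a test of how strongly a compound harms cultured cells. Compound 2 stands level with compound 1 at the digits shown, so there is no gap beyond the usual scatter between them.

Compound 3 `COc1ccc(-c2cc3c(OC)cc(OC)cc3n(CCCC#N)c2=O)cc1` has not yet been measured. It differs from compound 2 in one place, on a saturated chain carbon bound to an aromatic nitrogen, where 2-cyanoethyl takes the place of diethylcarbamoyl 2-cyanoethyl in place of diethylcarbamoyl on a saturated chain carbon bound to an aromatic nitrogen in the comparison of the two structures. Cut one bond further out, the same difference reads (diethylcarbamoyl)methyl to 3-cyanopropyl.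

For the measured compounds named here, no measured pair shows what a change at this place does, so the data offer no direction. The best guide is compound 2 itself, at 10000 nM in this assay on its own, and no step beyond the scatter is expected in either direction. The expected change is a 1.1-fold lower number from compound 2 to compound 3 (0.05 log units; within the scatter) as an estimate and no more. The estimated value for compound 3 is 9000 nM with an expected range from 3000 nM to 20000 nM on this thin evidence.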

Compound 3, half-maximal inhibitory concentration: 10000 nM
The estimate for compound 3 lay 1.1-fold (0.05 log units) below the measured number; low and high end bracket the measured number.
By their numbers in this assay, from the lowest: compounds 1, 2 and 3 (each within the scatter of the next).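

In this assay, for the compounds shown here, this is the first measured pair that changes the group on a saturated chain carbon bound to an aromatic nitrogen, and it reads no change at the digits printed from compound 2 to compound 3 (within the scatter) on going from diethylcarbamoyl to 2-cyanoethyl. The amide-bearing group and the smaller nitrile-bearing group therefore cannot be told apart on this read-out, so this particular swap at this place does not shift the number beyond ordinary experimental variation. Nothing measured here offers an explanation for why the two compounds read alike.

Going by these compounds alone, a single pair shows only that these two groups give matching results, not that every group at this place would do the same. From the compounds shown here alone, whether an amine, a carboxylic acid or a longer chain ending in a nitrile would give a lower number at this place stays open, as does the effect of a change at any other place on the shared core.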